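The compounds below may be only part of what the source reports. "The series", "measured", "known", "first", "only" and "open" are said of these compounds alone.

- Compound 1 `CC(=O)OC[C@H]1O[C@@H](n2c(SCc3cc4cc(F)ccc4oc3=O)nc3cncnc32)[C@H](O)[C@@H]1O`: 8600 nM
- Compound 2 `CC(=O)OC[C@H]1O[C@@H](n2c(SCc3cc4cc(Br)ccc4oc3=O)nc3cncnc32)[C@H](O)[C@@H]1O`: 31000 nM

For the measured compounds named here, in a functional assay on Huh-5-2 cells (Homo sapiens) for cytotoxicity, read by microscopy (a higher number here means that more compound is tolerated, a lower number that less compound is tolerated), compound 2 gives 31000 nM, the highest of the two numbers so far, and compound 1 gives 8600 nM. The next compound, compound 3 `CC(=O)OC[C@H]1O[C@@H](n2c(SCc3cc4cc(C)ccc4oc3=O)nc3cncnc32)[C@H](O)[C@@H]1O`, carries methyl in place of bromo on an aromatic carbon. Going by the values given here, one measured step bears on this change: a 3.6-fold higher number from compound 1 to compound 2 (0.56 log units; beyond the scatter), which is modest and came from bromo replacing fluoro on an aromatic carbon. Among the compounds with values here, no measured compound yet carries methyl, so this single step is a thin guide. A modest step or a smaller one is therefore expected in this assay, towards a lower number, since the bromo compound is the higher of the pair. The expected change is a 1.7-fold lower number from compound 2 to compound 3 (0.24 log units; within the scatter), and it may not clear the scatter. For compound 3 the estimated value is 18000 nM, with an expected range from 6000 nM to 50000 nM.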

Compound 3, half-maximal cytotoxic concentration: 16000 nM
Estimate against measurement, compound 3: 1.1-fold (0.05 log units) above; the range from low to high includes it.
By their numbers in this assay, from the lowest: compounds 1, 3 and 2 (each within the scatter of the next, the first and the last beyond it).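

In this assay, placing methyl at this position gives a 1.9-fold lower number from compound 2 to compound 3 (0.29 log units; within the scatter) when it replaces bromo and a 1.9-fold higher number from compound 1 to compound 3 (0.27 log units; within the scatter) when it replaces fluoro, so the methyl compound cannot be told apart from either halogen compound. For the compounds shown here, the only step here beyond the scatter is still a 3.6-fold higher number from compound 1 to compound 2 (0.56 log units; beyond the scatter), so this position separates the fluoro and bromo compounds, while methyl adds a third group that falls within the scatter of both. Nothing available explains these numbers.

Going by these compounds, it remains open whether a group of a different kind on this aromatic carbon, such as an amine or a carboxylic acid, would move the tolerated concentration beyond the scatter. A chloro or methoxy group would also test how far these three results extend to other small groups.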